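Trimming the butyl chain: compound 2 to compound 4

This account rests on a few compounds, and the source may have more. Where it says the series, first, only, none or still open, it means among the compounds named here.

In an ADME assay on DU-145 cells (Homo sapiens) for cytotoxicity, read by MTT assay, with a stated time of 72 h (on this read-out lower numbers stand for stronger inhibition of growth and higher numbers for weaker inhibition of growth), compound 2 `CCCCNC(=O)C1C(C(=O)O)[C@@H]2CC[C@H]1O2` gives 10000 nM. Compound 1 `C=CCNC(=O)C1C(C(=O)O)[C@@H]2CC[C@H]1O2` gives 10000 nM and compound 3 `O=C(O)C1C(C(=O)Nc2ccc(CO)cc2)[C@H]2CC[C@@H]1O2` gives 10000 nM. Among the measured compounds shown here, compound 2 therefore stands level with both, and the series so far shows no spread.

The next entry is compound 4 `CCCNC(=O)C1C(C(=O)O)[C@@H]2CC[C@H]1O2`. Its difference from compound 2 is hydrogen in place of methyl on a saturated chain carbon, three bonds along the chain from an amide-type nitrogen. In words, this is hydrogen in place of methyl on a saturated chain carbon, three bonds along the chain from an amide-type nitrogen, or butyl to propyl.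

For the measured compounds named here, one measured step bears on this change, a swap on the same amide chain: no change at the digits printed from compound 1 to compound 2 (within the scatter). Going by the values given here, that step is the only guide, and it gives no sign of sensitivity to the chain in this assay. No shift beyond the scatter is anticipated, in either direction. The expected step is no change at the digits printed from compound 2 to compound 4 (within the scatter). Compound 4 is estimated at 10000 nM, with an expected range of 6000 nM to 14000 nM.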

Compound 4, concentration for 50% growth inhibition: 10000 nM
The estimate for compound 4 equals the measured number at the digits printed, within the range that was stated.
By their numbers in this assay, from the lowest: compounds 1, 2, 3 and 4 (each within the scatter of the next).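

Shortening the saturated chain from butyl to propyl in this assay gives no change at the digits printed from compound 2 to compound 4 (within the scatter), so the flat result now covers a trim of the chain as well as the earlier swap at its end. Ethyl in place of vinyl gives no change at the digits printed from compound 1 to compound 4 (within the scatter), which shows that the same read-out holds when the two chains of this pair differ only at that end. No measurement at hand accounts for this lack of spread.

From the compounds shown here alone, it remains open whether a longer chain such as octyl, or an amine at the end of the chain, would separate from these compounds. With all four compounds level, the series does not yet show which parts of the amide substituent or the shared core can move the read-out in this assay.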